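From Benzylamino to 3-Fluorophenyl on the Carbonyl Carbon

A few compounds are considered here, and "the series" means these few. Any claim that something is new, unique, unknown or untested is made for them only; others in the source may bear on it.

Three measured compounds share one core and differ in the groups attached to it. Compound 1 `CN1CCC(C(=O)N2Cc3c(NC(=O)NCc4ccccc4)n[nH]c3C2(C)C)CC1` is the weakest of the three in a functional assay on A2780 cells (Homo sapiens) for antiproliferative activity, read by fluorescence, with a stated time of 72 h (on this read-out lower numbers stand for stronger inhibition and higher numbers for weaker inhibition), giving 2680 nM. Compound 2 `CCN1CCC(C(=O)N2Cc3c(NC(=O)CC(C)C)n[nH]c3C2(C)C)CC1` gives 410 nM in this assay, and compound 3 `CN1CCN(C(=O)N2Cc3c(NC(=O)c4ccc(F)cc4)n[nH]c3C2(C)C)CC1` gives 180 nM; both of these lie below the number for compound 1 by more than the scatter, so compound 1 stands clearly at the high end of the set.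

Compound 4 `CN1CCC(C(=O)N2Cc3c(NC(=O)c4cccc(F)c4)n[nH]c3C2(C)C)CC1` has not yet been measured. It differs from compound 1 in one place: 3-fluorophenyl in place of benzylamino on a carbonyl carbon. On the carbonyl carbon whose other neighbour is the amide-type nitrogen, benzylamino leaves and 3-fluorophenyl enters, so benzylcarbamoyl becomes (3-fluorophenyl)carbonyl. Among the compounds with values here, no measured pair isolates this change. Compound 3, the nearest point of comparison, gives 180 nM, though it differs from compound 1 in more than this one place.

The step from compound 1 to compound 4 in this assay is expected to be downward and beyond the scatter, namely a 7.7-fold lower number from compound 1 to compound 4 (0.88 log units; beyond the scatter). Compound 4 is estimated at 350 nM, with a range from 110 nM to 1100 nM.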

Compound 4, half-maximal inhibitory concentration: 200 nM
For compound 4 the middle estimate is 1.8-fold (0.24 log units) above the measured one; the measured number falls inside the stated range.
By their numbers in this assay, from the lowest: compounds 3 and 4 (each within the scatter of the next); then compound 2; then compound 1.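

In this assay, within the data shown here, the pair gives the first clean reading at this position: 3-fluorophenyl in place of benzylamino on the carbonyl carbon brings a 13-fold lower number from compound 1 to compound 4 (1.13 log units; beyond the scatter) with the rest of compound 1 unchanged. The number at this one place can therefore shift widely, and a single change here is enough to take compound 1 from the high end of the set to the low end. Benzylamino carries a hydrogen-bond donor and 3-fluorophenyl carries none, but nothing shown ties the size of the step to that difference or to the fluorine.

On these data alone, it remains open how plain phenyl, a pyridyl ring or benzyl on the same carbonyl carbon would compare. As far as these compounds go, it is also open whether this change gives a step of similar size when the ethyl-bearing piperidine amide replaces the methyl-bearing one.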